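Group change from compound 3 to compound 4

The compounds below may be only part of what the source reports. "The series", "measured", "known", "first", "only" and "open" are said of these compounds alone.

- compound 1 `CS(=O)(=O)NC(=O)CCc1cn(-c2ccc(Br)cc2)nc1-c1cccc(Cl)c1` gives 165000 nM
- compound 2 `CS(=O)(=O)NC(=O)CCc1cn(-c2ccc(Br)cc2)nc1-c1ccncc1` gives 185000 nM
- compound 3 `CS(=O)(=O)NC(=O)CCc1cn(-c2ccc(Br)cc2)nc1C1CCNCC1` gives 196000 nM

All three values come from a physicochemical assay for solubility, in phosphate buffer, measured as thermodynamic solubility, at pH 7.4 (on this read-out lower numbers stand for lower solubility and higher numbers for higher solubility), and sit within the scatter of one another, so compound 3 (196000 nM) is not separated from compound 1 or compound 2.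

The next compound is compound 4 `CS(=O)(=O)NC(=O)CCc1cn(-c2ccc(Br)cc2)nc1-c1ccc(N)cc1`, and the change is 4-aminophenyl in place of piperidin-4-yl on an aromatic carbon.

Among the compounds with values here, three measured steps bear on this place: a 1.1-fold higher number from compound 1 to compound 2 (0.05 log units; within the scatter), a 1.2-fold higher number from compound 1 to compound 3 (0.07 log units; within the scatter) and a 1.1-fold higher number from compound 2 to compound 3 (0.03 log units; within the scatter). Within the data shown here, all three lie within the scatter, though they cover only three groups, and no measured compound yet carries 4-aminophenyl. On these steps, no change beyond the scatter is expected in this assay. The expected step is a 1.1-fold lower number from compound 3 to compound 4 (0.05 log units; within the scatter), which is no real shift. Compound 4 is estimated at 175000 nM, with an expected range of 100000 nM to 270000 nM.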

Compound 4, solubility: 160000 nM
For compound 4 the middle estimate is 1.1-fold (0.04 log units) above the measured one; the measured number falls inside the stated range.
By their numbers in this assay, from the lowest: compounds 4, 1, 2 and 3 (each within the scatter of the next).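

In this assay, 4-aminophenyl joins the groups at this position on the five-membered aromatic ring, and the steps are a 1.2-fold lower number from compound 3 to compound 4 (0.09 log units; within the scatter) and a 1.2-fold lower number from compound 2 to compound 4 (0.06 log units; within the scatter) and a 1.0-fold lower number from compound 1 to compound 4 (0.01 log units; within the scatter) with all three printed as within the scatter. The expected lack of separation therefore now holds for a fourth group, and none of the four groups at this position is set apart from the others on this read-out. Nothing available accounts for this flat read-out.

Going by these compounds, it remains open whether a carboxylic acid, a small alkyl group or a longer amine chain at this position would give a step beyond the scatter. On these data alone, the 4-bromophenyl and 2-((methylsulfonyl)carbamoyl)ethyl groups are common to all four compounds, and what replacing either would do at this position also remains open.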